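The source may report more compounds than this note shows. Statements on the series, on what has been measured and on what is new or still open speak of the compounds shown alone.

Measured in a functional assay on HeLa cells (Homo sapiens) for cytotoxicity, read by MTT assay, with a stated time of 48 h; a higher number here means a weaker inhibitor, a lower number a stronger inhibitor:
Compound 1 `CC[C@H](C)[C@H](NC(=O)[C@@H](NC(=O)OC(C)(C)C)C(C)C)C(=O)N1Cc2cc(OCC(=O)NO)ccc2C[C@H]1C(=O)Nc1ccc(OC)cc1`: 167000 nM
Compound 2 `CC[C@H](C)[C@@H](CN1Cc2cc(OCC(=O)NO)ccc2C[C@H]1C(=O)Nc1ccc(OC)cc1)NC(=O)OC(C)(C)C`: 29200 nM

Of these two compounds, compound 2 stands lowest at 29200 nM, the stronger of the pair. Going by the values given here, its only neighbour, compound 1, gives a higher number, and that gap lies beyond the usual scatter of repeat measurements.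

Compound 3 `CC[C@H](C)[C@@H](CN1Cc2cc(OCC(=O)NO)ccc2C[C@H]1C(=O)Nc1ccc(OC)cc1)NC(=O)CC(C)(C)C` departs from compound 2 at a single place, with neopentyl in place of tert-butoxy on a carbonyl carbon. Among the compounds with values here, no pair of measured compounds shows this change, so the data offer no direct guide to its size, and the expectation starts from compound 2 at 29200 nM. In this assay, the expected result is a 1.2-fold lower number from compound 2 to compound 3 (0.07 log units; within the scatter), an estimated step within the scatter and without a firm direction. For compound 3 the estimate is 25000 nM, with an expected range from 8000 nM to 75000 nM.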

Compound 3, half-maximal inhibitory concentration: 63500 nM
Compound 3: the middle estimate sits 2.5-fold (0.40 log units) below what was measured; measured number inside the range.
By their numbers in this assay, from the lowest: compound 2; then compound 3; then compound 1.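

In this assay the exchange of tert-butoxy for neopentyl on a carbonyl carbon gives a 2.2-fold higher number from compound 2 to compound 3 (0.34 log units; beyond the scatter) and so shows that this place responds to the group it carries. Going by these compounds alone, the step is modest, yet it is the first measured change at this position, and it turns (tert-butoxycarbonyl)amino into (neopentylcarbonyl)amino, with a carbon taking the place of the oxygen while the heavy-atom count stays the same. No measurement at hand explains the shift.

The compounds shown leave open how a smaller group such as methyl, or an amine such as dimethylamino, would read on the same carbonyl carbon. They also leave open whether this step would recur with a different substituent elsewhere on the shared core.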